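This account rests on a few compounds, and the source may have more. Where it says the series, first, only, none or still open, it means among the compounds named here.

Of the compounds shown here, three built on one shared core have been tested in an assay on LX2 cells for inhibition of COL1A1 promoter (Homo sapiens), read by a luciferase reporter, with a stated time of 24 h, tested at 50 uM (a lower number here means a weaker effect, a higher number a stronger effect of the compound at the concentration tested), and a fourth awaits its reading.

Compound 1 `Cc1ccc(-n2cc(C(=O)Nc3cc(F)cc(F)c3)c(=O)c3ccc(N(C)C)nc32)cc1OCCCCCCC[N+]12CCN(CC1)CC2` gives 9.71% in this assay. Compound 2 `CN(C)c1ccc2c(=O)c(C(=O)Nc3cc(F)cc(F)c3)cn(-c3ccc(Cl)c(OCCCCCCC[N+]45CCN(CC4)CC5)c3)c2n1` carries one change against compound 1, (chloro in place of methyl on an aromatic carbon), and compound 2 gives 18.7%, a step of a number 9 percentage points higher from compound 1 to compound 2 (within the scatter). Compound 3 `Cc1ccc(-n2cc(C(=O)Nc3cc(F)cc(F)c3)c(=O)c3ccc(N(C)C)nc32)cc1OCCCCCCC[n+]1ccccc1` differs from compound 1 at the far end of the chain, (a group of 6 heavy atoms (5 carbon, 1 nitrogen; one six-membered aromatic ring with 1 hetero atom) in place of a group of 8 heavy atoms (6 carbon, 2 nitrogen; 2 six-membered non-aromatic rings with 2 hetero atoms each), on a saturated chain carbon, seven bonds along the chain from an oxygen on an aromatic ring), and compound 3 gives 22.2%, a step of a number 12.5 percentage points higher from compound 1 to compound 3 (beyond the scatter). The reading of compound 2 and that of compound 3 lie close to each other.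

Compound 4 `CN(C)c1ccc2c(=O)c(C(=O)Nc3cc(F)cc(F)c3)cn(-c3ccc(Cl)c(OCCCCCCC[n+]4ccccc4)c3)c2n1` stands to compound 3 as compound 2 stands to compound 1: the change is chloro in place of methyl on an aromatic carbon, at a place described in the same words for both pairs, so it is the same change made on the core of compound 3 rather than on the core of compound 1. How those two cores differ is set out above as the change from compound 1 to compound 3.

Among the compounds with values here, the only guide to this change is the single measured pair, where the step from compound 1 to compound 2 was a number 9 percentage points higher from compound 1 to compound 2 (within the scatter). Carrying that step over, the expected step from compound 3 to compound 4 is a number 6.8 percentage points higher from compound 3 to compound 4 (within the scatter). Compound 4 is therefore expected to give about 29% in this assay, most likely between 16% and 42%, a range kept wide since it rests on one pair alone.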

Compound 4, a percentage reported as inhibition, at one concentration (the size of the read-out at that concentration, not a potency): 77.9%
The estimate for compound 4 lay 48.9 percentage points below the measured number; the whole stated range lies below it.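

In this assay, chloro in place of methyl gives a number 55.7 percentage points higher from compound 3 to compound 4 (beyond the scatter), and this step does not match the one seen for the same change on the core of compound 1: the same change on two cores in this assay, a number 9 percentage points higher (within the scatter) from compound 1 to compound 2 and a number 55.7 percentage points higher (beyond the scatter) from compound 3 to compound 4, 46.7 percentage points apart, beyond the scatter of two such steps

The change at the far end of the chain behaves the same way, with the six-membered aromatic ring giving a number 59.2 percentage points higher from compound 2 to compound 4 (beyond the scatter), so neither change on its own predicted what the two do together: the same change on two cores in this assay, a number 12.5 percentage points higher (beyond the scatter) from compound 1 to compound 3 and a number 59.2 percentage points higher (beyond the scatter) from compound 2 to compound 4, 46.7 percentage points apart, beyond the scatter of two such steps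

In these four compounds, then, the size of the chloro step depends on the group at the far end of the chain, and a step measured on one core proved a poor guide to the same step on another; this does not show why the two changes act together, nor whether the same would hold in other compounds, and each reading comes from a single concentration and is not a potency.

The compounds shown leave open whether bromo or trifluoromethyl in place of the chloro would also give a high reading with the same group at the chain end. They also leave open whether a shorter chain, or a trimethylammonium group at its end, would keep the reading of compound 4.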